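A Methyl on the Indazole Nitrogen of a Urea Antagonist

The compounds below may be only part of what the source reports. "The series", "measured", "known", "first", "only" and "open" are said of these compounds alone.

Two measured compounds share a urea-linked core. Compound 1 `CC(C)c1ccc(-n2nc(C(F)(F)F)cc2CNC(=O)Nc2cccc3[nH]ncc23)cc1` and compound 2 `Cc1ccc(-n2nc(C(F)(F)F)cc2CNC(=O)Nc2cccc3[nH]ncc23)cc1C` differ only in the group on the aromatic nitrogen of the five-membered ring that carries the trifluoromethyl group. In an assay on CHO-K1 cells for antagonist activity at transient receptor potential cation channel subfamily V member 1 (Homo sapiens), read by FLIPR and calcium flux, with a stated time of 6 min (a lower number here means a stronger inhibitor, a higher number a weaker inhibitor), compound 1 gives 4.1 nM, and in this assay compound 2 gives 2.8 nM. The step of a 1.5-fold lower number from compound 1 to compound 2 (0.17 log units; within the scatter) is small, so compound 2 has the lower of the two numbers while staying within the usual scatter of compound 1.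

Compound 3 `Cc1ccc(-n2nc(C(F)(F)F)cc2CNC(=O)Nc2cccc3c2cnn3C)cc1C` is not yet measured. It differs from compound 2 in one place: methyl in place of hydrogen on an aromatic nitrogen. Among the measured compounds shown here, this change sits at the other end of the molecule from the only measured step, which swapped one aryl group for another on the opposite aromatic nitrogen, so that step tells nothing about what replacing the hydrogen on the indazole nitrogen with a methyl will do. For the measured compounds named here, no measured pair here bears on this change.

Going by the values given here, with no guiding step, the estimate for compound 3 rests on the value of compound 2 alone and on a wide range: compound 3 is expected to give about 12 nM, between 2.5 nM and 60 nM, meaning an expected step of a 4.3-fold higher number from compound 2 to compound 3 (0.63 log units; beyond the scatter).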

Compound 3, inhibition constant: 3.5 nM
Compound 3: the middle estimate sits 3.4-fold (0.54 log units) above what was measured; the range from low to high includes it.
By their numbers in this assay, from the lowest: compounds 2, 3 and 1 (each within the scatter of the next).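

In this assay, the step of a 1.3-fold higher number from compound 2 to compound 3 (0.10 log units; within the scatter) shows that a methyl can stand in place of the hydrogen on this aromatic nitrogen without moving the number beyond the scatter, so the 1H-indazol-4-yl and 1-methyl-1H-indazol-4-yl compounds cannot be told apart here. Among the compounds shown here, the earlier compounds varied only the aryl group at the other end of the molecule, so this pair is the first reading at this position, and it shows that, at least with the 3,4-dimethylphenyl group in place, a hydrogen on this nitrogen is not needed for a number in the range of compound 2. Nothing available here explains why the two numbers fall so close together.

From the compounds shown here alone, it remains open whether an ethyl group, a longer chain or a chain ending in an amine or a carboxylic acid on this same nitrogen would also stay within the scatter of compound 2. Going by these compounds, it is equally open whether the methyl would give a similar result alongside the 4-isopropylphenyl group of compound 1, since a single pair cannot establish a trend.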